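A Chloro-for-Methyl Swap on a Fused Core

This account rests on a few compounds, and the source may have more. Where it says the series, first, only, none or still open, it means among the compounds named here.

Measured compounds:
- Compound 1, `Cc1cc(C)nc(SCc2cc(=O)c3cc(Cl)ccc3o2)n1`, in a functional assay on MCF7 cells (Homo sapiens) for cytotoxicity, read by MTT assay, with a stated time of 72 h (on this read-out higher numbers stand for weaker inhibition and lower numbers for stronger inhibition), reaches only a limit of > 25000 nM.
- Compound 2, `Cc1ccc2oc(CSc3nc(C)cc(C)n3)cc(=O)c2c1`, in this assay reaches only a limit of > 25000 nM.
- Compound 3, `Cc1ccc2oc(CSc3nnc(C)s3)cc(=O)c2c1`, in this assay reaches only a limit of > 25000 nM.

Among the compounds with values here, none of the measured compounds gives a number in this assay; every value is a limit, as the limit of > 25000 nM in this assay, at which 3 of the 3 values shown sit, records. Compound 2 and compound 1 differ in one place, (chloro in place of methyl on an aromatic carbon), yet the step that the two limits leave unreadable from compound 2 to compound 1 cannot be read, since both ends are limits. Compound 3 carries a different core from compound 2; the difference between the two cores is not broken down here.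

Compound 4, `Cc1nnc(SCc2cc(=O)c3cc(Cl)ccc3o2)s1`, has not been measured. It relates to compound 3 exactly as compound 1 relates to compound 2, through the same change, (chloro in place of methyl on an aromatic carbon), at a place described in the same words. With the earlier step unreadable and all measured values sitting at the limit, the expected step that the limit leaves unreadable from compound 3 to compound 4 rests only on that shared pattern. Compound 4 is therefore expected to give 30000 nM in this assay, most likely again as a limit rather than a number.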

Compound 4, half-maximal inhibitory concentration: > 25000 nM
Compound 4: only a limit was reported; the forecaster's own chance of this, stated with the estimate: 85%; the middle value lies beyond the limit too.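

Compound 4 gives > 25000 nM in this assay, which is a limit and not a number. Within the data shown here, compound 3 also stands at a limit, so no step from compound 3 to compound 4 can be read. The compounds shown leave open whether chloro in place of methyl changes cytotoxicity at all, with every value at one shared limit: the limit of > 25000 nM in this assay, at which 4 of the 4 values shown sit.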